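Swapping the aryl group on the exocyclic double bond

This account rests on a few compounds, and the source may have more. Where it says the series, first, only, none or still open, it means among the compounds named here.

In a functional assay on A549 cells (Homo sapiens) for cytotoxicity, read by sulforhodamine B assay, with a stated time of 48 h (on this read-out lower numbers stand for stronger inhibition and higher numbers for weaker inhibition), compound 1, `CC(=O)OC[C@H]1O[C@@H](n2cc(CN3C(=O)/C(=C/c4ccccc4)c4ccccc43)nn2)[C@H](OC(C)=O)[C@@H](OC(C)=O)[C@@H]1OC(C)=O`, gives 20600 nM. Compound 2, `CC(=O)OC[C@H]1O[C@@H](n2cc(CN3C(=O)/C(=C/C=C/c4ccccc4)c4ccccc43)nn2)[C@H](OC(C)=O)[C@@H](OC(C)=O)[C@@H]1OC(C)=O`, returns only a limit in this assay, > 100000 nM. Compound 3, `CC(=O)OC[C@H]1O[C@@H](n2cc(CN3C(=O)/C(=C/c4ccc5ccccc5c4)c4ccccc43)nn2)[C@H](OC(C)=O)[C@@H](OC(C)=O)[C@@H]1OC(C)=O`, gives 30900 nM, the highest of the two plain numbers, with compound 1 nearest at a 1.5-fold higher number from compound 1 to compound 3 (0.18 log units; within the scatter). The change from compound 1 to compound 2 brought an at least 4.8-fold higher number from compound 1 to compound 2 (0.68 log units; beyond the scatter), and from compound 2 to compound 3 an at least 3.2-fold lower number from compound 2 to compound 3 (0.51 log units; beyond the scatter); the limit of > 100000 nM in this assay, at which 1 of the 3 values shown sits, is what sets these two steps.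

Compound 4, `CC(=O)OC[C@H]1O[C@@H](n2cc(CN3C(=O)/C(=C/c4ccco4)c4ccccc43)nn2)[C@H](OC(C)=O)[C@@H](OC(C)=O)[C@@H]1OC(C)=O`, differs from compound 3 by furan-2-yl in place of naphthalen-2-yl on a double-bonded chain carbon bound to a double-bonded ring carbon. Among the compounds with values here, no measured step exchanges an aryl group for a smaller aryl group. The steps at hand show that trading phenyl for naphthalen-2-yl stays within the scatter, while lengthening the chain with 2-phenylethenyl weakens inhibition beyond it. Compound 4 keeps a single ring directly on the chain carbon, so the number in this assay is expected to stay close to that of compound 3, with an estimated 1.4-fold lower number from compound 3 to compound 4 (0.15 log units; within the scatter). Compound 4 is therefore estimated at 22000 nM, within a range from 8000 nM to 70000 nM.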

Compound 4, half-maximal inhibitory concentration: 14500 nM
The estimate for compound 4 lay 1.5-fold (0.18 log units) above the measured number; the range from low to high includes it.
By their numbers in this assay, from the lowest: compounds 4, 1 and 3 (each within the scatter of the next, the first and the last beyond it). At a limit, above all of these: compound 2.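

Until now, no swap of one ring for another on the double-bonded chain carbon had moved the number beyond the scatter, but furan-2-yl in place of naphthalen-2-yl does, with a 2.1-fold lower number from compound 3 to compound 4 (0.33 log units; beyond the scatter). Set against phenyl in this assay, furan-2-yl cannot be told apart, with a 1.4-fold lower number from compound 1 to compound 4 (0.15 log units; within the scatter). Compound 2 stands at a limit, and that limit alone sets the step of an at least 6.8-fold lower number from compound 2 to compound 4 (0.83 log units; beyond the scatter): the limit of > 100000 nM in this assay, at which 1 of the 4 values shown sits.

In the step from naphthalen-2-yl, the ring size and the ring oxygen change together, so the compounds shown cannot separate the two. Also open, as far as these compounds go, is how a pyridin-3-yl or thiophen-2-yl ring, or a phenyl carrying a methoxy group or a chlorine, would read at this position.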